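Cyclohexyl for Dimethoxyphenyl on Two Related Cores

This account rests on a few compounds, and the source may have more. Where it says the series, first, only, none or still open, it means among the compounds named here.

Measured so far in an ADME assay on Vero cells (Chlorocebus sabaeus) for cytotoxicity, read by MTT assay, with a stated time of 48 h; a higher number here means a weaker inhibitor, a lower number a stronger inhibitor:
compound 1 `O=c1nc(NCC2CCCCC2)oc2c([N+](=O)[O-])cc(C(F)(F)F)cc12` gives 29.7 ug/mL
compound 2 `COc1ccc(CNc2nc(=O)c3cc(C(F)(F)F)cc([N+](=O)[O-])c3o2)cc1OC` gives 29.2 ug/mL
compound 3 `COc1ccc(CNc2cc(=O)c3cc(C(F)(F)F)cc([N+](=O)[O-])c3s2)cc1OC` gives only a limit, > 64 ug/mL

Compound 2 and compound 1 share one core and differ by a single change: cyclohexyl in place of 3,4-dimethoxyphenyl on a saturated chain carbon bound to a nitrogen on an aromatic ring. In this assay this change gives a 1.0-fold higher number from compound 2 to compound 1 (0.01 log units; within the scatter). Compound 3 carries a different core; the difference between the two cores and the core of compound 2 is not broken down here. For compound 3 the assay reports a limit and no number.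

Compound 4 `O=c1cc(NCC2CCCCC2)sc2c([N+](=O)[O-])cc(C(F)(F)F)cc12` has not yet been measured. It stands to compound 3 as compound 1 stands to compound 2, by the same change: cyclohexyl in place of 3,4-dimethoxyphenyl on a saturated chain carbon bound to a nitrogen on an aromatic ring.

Compound 4 is expected to sit at 80 ug/mL in this assay, within a range from 45 ug/mL to 160 ug/mL. This expectation rests on the same change leaving compound 2 to compound 1 unmoved, so the step from compound 3 to compound 4 is estimated at a step that the limit leaves unreadable from compound 3 to compound 4, and because of the limit of > 64 ug/mL in this assay, at which 1 of the 3 values shown sits, the assay will most likely report only a limit for compound 4 as well.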

Compound 4, half-maximal inhibitory concentration: > 64 ug/mL
Compound 4 was reported as a limit; the forecaster's own chance of this, stated with the estimate: 70%; the middle value does not contradict the limit.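

In this assay, compound 3 and compound 4 are each reported only as a limit, and no step between them can be read, because both sit at the same limit: the limit of > 64 ug/mL in this assay, at which 2 of the 4 values shown sit.

The compounds shown leave open whether cyclohexyl in place of 3,4-dimethoxyphenyl changes the number on the core of compound 3, where neither compound has a measured number.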